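Halogen change on the phenyl group: cytotoxicity notes

The compounds below may be only part of what the source reports. "The series", "measured", "known", "first", "only" and "open" are said of these compounds alone.

Measured so far:
compound 1 `c1ccc([C@@H]2C[C@@H]3Cc4ccc5ccccc5c4N2O3)cc1` — in an ADME assay on THP-1 cells (Homo sapiens) for cytotoxicity, read by MTT assay, with a stated time of 72 h (a higher number here means that more compound is tolerated, a lower number that less compound is tolerated), compound 1 gives > 350000 nM
compound 2 `Fc1ccc([C@@H]2C[C@@H]3Cc4ccc5ccccc5c4N2O3)cc1` — in this assay compound 2 gives > 300000 nM.

The value that compound 1 shows, > 350000 nM, is a limit of the assay, not a number. For compound 2 the value > 300000 nM is likewise a limit. Within the data shown here, compound 2 therefore stands at the limit in this assay, and the one available step, a step that the two limits leave unreadable from compound 1 to compound 2, has no readable size: the two limits the limit of > 300000 nM in this assay, at which 1 of the 2 values shown sits, and the limit of > 350000 nM in this assay, at which 1 of the 2 values shown sits, leave it open.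

Compound 3 `Clc1ccc([C@@H]2C[C@@H]3Cc4ccc5ccccc5c4N2O3)cc1` is not yet measured. It differs from compound 2 by chloro in place of fluoro on an aromatic carbon. Among the measured compounds shown here, no measured step bears on this change, since the hydrogen-to-fluoro step is unreadable. Compound 3 is therefore expected to show no step beyond the scatter, with an estimated step of a number no higher from compound 2 to compound 3 (the limit leaves the size open). Compound 3 is expected to give 300000 nM, estimated between 100000 nM and 600000 nM, most likely reported again only as a limit.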

Compound 3, half-maximal cytotoxic concentration: > 300000 nM
Compound 3 ended at the assay's limit (the forecaster's own chance of this, stated with the estimate: 75%); the middle value sits exactly at the limit.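

In this assay compound 3 gives > 300000 nM, which is a limit of the assay. No step among compound 1, compound 2 and compound 3 can be read: the limit of > 300000 nM in this assay, at which 2 of the 3 values shown sit.

The compounds shown leave open whether hydrogen, fluoro or chloro on the aromatic carbon makes any difference in this assay.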